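This account rests on a few compounds, and the source may have more. Where it says the series, first, only, none or still open, it means among the compounds named here.

In an ADME assay on the whole organism with Oryza sativa as the target, tested at 0.1 uM (on this read-out higher numbers stand for a weaker effect at the one concentration tested and lower numbers for a stronger effect), compound 1 `Cc1ccc(NC(=O)N[C@H](C)c2ccccc2)cc1` gives 100%.
In this assay compound 2 `CCc1ccccc1NC(=O)N[C@H](C)c1ccccc1` gives 101%.
In this assay compound 3 `C[C@@H](NC(=O)Nc1ccccc1F)c1ccccc1` gives 97%.

Compound 3 sits at the low end of these three numbers, yet its gaps to compound 1 and to compound 2 are both within the scatter, so the three compounds cannot be told apart. Among the compounds with values here, the only single-point step among them, a number 4 percentage points lower from compound 2 to compound 3 (within the scatter), is also within the scatter. Compound 4 `Cc1ccc(NC(=O)N[C@H](C)c2ccccc2)c(F)c1` is not yet measured; it differs from compound 3 by methyl in place of hydrogen on an aromatic carbon. Within the data shown here, no measured step covers methyl in place of hydrogen, and the values of compound 1 and compound 3 do not separate either, so compound 4 is expected to show no step beyond the scatter, a number 1 percentage points higher from compound 3 to compound 4 (within the scatter). Compound 4 is estimated at 98%, within 88% to 108%.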

Compound 4, a percentage reported as activity, at one concentration (the size of the read-out at that concentration, not a potency): 98%
Compound 4: the middle estimate sits on the measured number at the digits printed, within the range that was stated.
By their numbers in this assay, from the lowest: compounds 3, 4, 1 and 2 (each within the scatter of the next).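

In this assay, methyl in place of hydrogen, para to a large group and meta to a fluoro group, gives a number 1 percentage points higher from compound 3 to compound 4 (within the scatter) and bringing in the fluoro group instead gives a number 2 percentage points lower from compound 1 to compound 4 (within the scatter) as its counterpart. Within the data shown here, these are the first steps here that put a group in place of hydrogen, and neither goes beyond the scatter. Nothing measured here offers an explanation for this result. Still open, on these data alone, is whether a different group at this position, such as an amine or a carboxylic acid, would move the number beyond the scatter. As far as these compounds go, it is also open whether any change on this ring can shift this read-out at all.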